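This account rests on a few compounds, and the source may have more. Where it says the series, first, only, none or still open, it means among the compounds named here.

Measured in a functional assay on HEL cells (Homo sapiens) for cytotoxicity, read by microscopy; on this read-out lower numbers stand for higher toxicity in this test and higher numbers for lower toxicity in this test:
compound 1 `CCCCCCCCc1cc2cn([C@H]3C[C@H](O)[C@@H](CO)O3)c(=O)nc2o1` gives > 50000 nM, a limit of the test.
compound 2 `CCCCCCCCCCc1cc2cn([C@H]3C[C@H](O)[C@@H](CO)O3)c(=O)nc2o1` gives > 50000 nM, a limit of the test.
compound 3 `C=CCCCCc1cc2cn([C@H]3C[C@H](O)[C@@H](CO)O3)c(=O)nc2o1` gives > 200000 nM, a limit of the test.

Compound 3 stands at a limit in this assay, and the two other values shown are limits as well, so none of the steps among the three is readable: a step that the two limits leave unreadable from compound 1 to compound 2, a step that the two limits leave unreadable from compound 1 to compound 3, a step that the two limits leave unreadable from compound 2 to compound 3. Compound 4 `C=CCCCCCCCCc1cc2cn([C@H]3C[C@H](O)[C@@H](CO)O3)c(=O)nc2o1` differs from compound 3 by hex-5-en-1-yl in place of vinyl on a saturated chain carbon, four bonds along the chain from an aromatic carbon. The steps from compound 1 and compound 2 to compound 3, which swap a saturated chain for the vinyl at the same place, bear on this change, and both are unreadable. Two values sit at the limit of > 50000 nM in this assay, at which 2 of the 3 values shown sit, and one at the limit of > 200000 nM in this assay, at which 1 of the 3 values shown sits. No direction or size of step can be read, and compound 4 is expected to stay at a limit, the expected step being an at least 2.0-fold lower number from compound 3 to compound 4 (0.30 log units; that floor lies within the scatter). Compound 4 is estimated at 100000 nM, between 50000 nM and 300000 nM.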

Compound 4, minimum cytotoxic concentration: > 50000 nM
Compound 4: a limit, no number; the forecaster's own chance of this, stated with the estimate: 85%; the middle value lies beyond the limit too.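

In this assay, for the compounds shown here, compound 4 gives > 50000 nM, a limit of the test, so no step to compound 4 from compound 1, compound 2 or compound 3 can be read. The compounds shown leave open whether chain length or a terminal double bond has any effect in this assay.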